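Cytotoxicity series: one methyl added on the side chain

The compounds below may be only part of what the source reports. "The series", "measured", "known", "first", "only" and "open" are said of these compounds alone.

Measured so far in a functional assay on NALM-6 cells (Homo sapiens) for cytotoxicity, read by MTT assay, with a stated time of 48 h; on this read-out lower numbers stand for stronger inhibition and higher numbers for weaker inhibition:
compound 1, `C=C1CC(c2ccc(Br)cc2)OC1=O`, 85300 nM
compound 2, `CC(C)/C=C1\CC(c2ccccc2)N(C)C1=O`, 351000 nM
compound 3, `C=C1CC(C)OC1=O`, 41000 nM

Compound 3 stands lowest of the three numbers in this assay. Compound 1 sits higher, beyond the scatter, and compound 2 higher still, also beyond the scatter.

Compound 4, `C=C1CC(CC)OC1=O`, differs from compound 3 by methyl in place of hydrogen on a saturated chain carbon bound to a saturated ring carbon. For the measured compounds named here, no pair of measured compounds isolates a change of this kind, so the measured set gives no direct guide. A change this small is expected to move the number little in this assay, within the scatter, if anything slightly downward. The estimated step is a 1.2-fold lower number from compound 3 to compound 4 (0.07 log units; within the scatter). Compound 4 is expected to give 35000 nM in this assay, with a range from 15000 nM to 80000 nM.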

Compound 4, half-maximal inhibitory concentration: 51600 nM
The estimate for compound 4 lay 1.5-fold (0.17 log units) below the measured number; low and high end bracket the measured number.
By their numbers in this assay, from the lowest: compounds 3, 4 and 1 (each within the scatter of the next, the first and the last beyond it); then compound 2.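

Methyl in place of hydrogen on a saturated chain carbon bound to a saturated ring carbon gives, in this assay, a 1.3-fold higher number from compound 3 to compound 4 (0.10 log units; within the scatter) at this position. For the compounds shown here, this is the first single-place step, and it shows that methyl to ethyl here does not move the number beyond the scatter. No evidence is available on what underlies this result.

As far as these compounds go, whether a longer chain at this position would stay within the scatter of compound 3 remains open. An amine or a carboxylic acid on the chain is equally unresolved.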